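The compounds below may be only part of what the source reports. "The series", "measured", "known", "first", "only" and "open" are said of these compounds alone.

Measured so far:
- compound 1, `Fc1ccccc1Cn1nc(-c2ccccn2)c2cccnc21`: 4800 nM
- compound 2, `Fc1ccccc1Cn1nc(-c2cc[nH]n2)c2cccnc21`: 1800 nM
- compound 3, `CC(C)(C)c1cnc(-c2nn(Cc3ccccc3F)c3ncccc23)nc1N`: 709000 nM

The three compounds share a core and were tested in a functional assay (aorta) with Oryctolagus cuniculus as the target; a higher number here means a weaker inhibitor, a lower number a stronger inhibitor. Compound 1 gives 4800 nM, and a single change, a 2.7-fold lower number from compound 1 to compound 2 (0.43 log units; beyond the scatter), brings compound 2 to 1800 nM. Compound 3 stands apart: with 709000 nM it has by far the highest number of the three, a weaker inhibitor than compound 1 and compound 2 by a wide margin, well beyond the scatter.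

Compound 4, `N#Cc1cnc(-c2nn(Cc3ccccc3F)c3ncccc23)nc1N`, has not yet been measured. It differs from compound 3 in one place: cyano in place of tert-butyl on an aromatic carbon. Going by the values given here, no measured step concerns this part of the molecule; the only step on record, from compound 1 to compound 2, alters a different position and says nothing about swapping tert-butyl for cyano. The expectation for compound 4 therefore rests on compound 3 alone, with 709000 nM as the anchor and no direction to lean. The estimate is a 2.4-fold lower number from compound 3 to compound 4 (0.37 log units; beyond the scatter), little different from compound 3. Compound 4 is thus expected to give about 300000 nM, within a broad range from 30000 nM to 3000000 nM.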

Compound 4, half-maximal inhibitory concentration: 391000 nM
Compound 4: middle estimate off by 1.3-fold (0.12 log units), on the low side; the range from low to high includes it.
By their numbers in this assay, from the lowest: compound 2; then compound 1; then compounds 4 and 3 (each within the scatter of the next).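

In this assay, cyano in place of tert-butyl on the aromatic carbon ortho to the amino group gives a 1.8-fold lower number from compound 3 to compound 4 (0.26 log units; within the scatter) and so leaves compound 3 and compound 4 indistinguishable. Going by these compounds alone, this is the first reading at this position: a group of 4 heavy atoms with 0 hydrogen-bond acceptors and a group of 2 heavy atoms with 1 hydrogen-bond acceptor give numbers that cannot be separated here. No supporting measurement is available to explain this result.

From the compounds shown here alone, it remains open whether any group at this position could shift the number beyond the scatter, for example a methyl, a carboxylic acid or a longer alkyl chain. Going by these compounds, compound 3 and compound 4 both carry the amino group, so its contribution also remains unknown.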